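The source may report more compounds than this note shows. Statements on the series, on what has been measured and on what is new or still open speak of the compounds shown alone.

Working notes on the series

Of the compounds shown here, three of this set have been measured in a functional assay on HeLa cells (Homo sapiens) for cytotoxicity, read by XTT assay, with a stated time of 72 h; on this read-out higher numbers stand for weaker inhibition and lower numbers for stronger inhibition. Compound 1 `CCn1ccc2cc(Cc3cc(OC)c(OC)c(OC)c3)ccc21` gives 17 nM. Compound 3 `COc1cc(Cc2ccc3c(ccn3C)c2)cc(OC)c1OC` gives 30 nM. Compound 2 `COc1ccc(C(O)c2ccc3c(ccn3C)c2)c(OC)c1OC` gives 2500 nM, the highest number of the three; against compound 3 its number is higher by an amount beyond the scatter, and against compound 1 likewise. How compound 2 and compound 3 differ is not broken down here.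

One change occurs twice among the compounds shown. From compound 3 to compound 1 it is methyl in place of hydrogen on a saturated chain carbon bound to an aromatic nitrogen, and the step it made was a 1.8-fold lower number from compound 3 to compound 1 (0.25 log units; within the scatter). From compound 2 to compound 4 `CCn1ccc2cc(C(O)c3ccc(OC)c(OC)c3OC)ccc21`, still to be measured in this assay, the same change is made: methyl in place of hydrogen on a saturated chain carbon bound to an aromatic nitrogen. Both changes sit at the same place, on a saturated chain carbon bound to an aromatic nitrogen.

The expectation for compound 4 in this assay rests on compound 1 because a 1.8-fold lower number from compound 3 to compound 1 (0.25 log units; within the scatter) was within the scatter, so a step of a 1.7-fold lower number from compound 2 to compound 4 (0.22 log units; within the scatter) is estimated, and compound 4 is expected near 1500 nM, between 600 nM and 5000 nM.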

Compound 4, half-maximal inhibitory concentration: < 1000 nM
Compound 4 ended at the assay's limit; the forecaster's own chance of this, stated with the estimate: 3%; middle value at least 1.5-fold (0.17 log units) from the limit.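

Compound 4 stands at a limit of the assay and not at a number: the limit of < 1000 nM in this assay, at which 1 of the 4 values shown sits.

In this assay methyl in place of hydrogen on a saturated chain carbon bound to an aromatic nitrogen gives an at least 2.5-fold lower number from compound 2 to compound 4 (0.39 log units; beyond the scatter), so on the core of compound 2 the change moves the number by more than the scatter, while on the core of compound 3 its step does not. Whether the change carries from one core to the other with the same size is not shown, and a real difference between the two cores cannot be claimed either: the same change on two cores in this assay, a 1.8-fold lower number (0.25 log units; within the scatter) from compound 3 to compound 1 and an at least 2.5-fold lower number (0.39 log units; beyond the scatter) from compound 2 to compound 4; the limit leaves it open whether they differ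

The compounds shown carry only the shorter chains named here, the one ending in methyl and the ethyl form, so a longer chain such as propyl, or a chain ending in an amine or a carboxylic acid, stays open. Going by these compounds, the exact value of compound 4 stays open as well, and with it the full size of its step.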